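Series notes: aryl ether chain variation and microsomal half-life

This account rests on a few compounds, and the source may have more. Where it says the series, first, only, none or still open, it means among the compounds named here.

compound 1, `Cc1cc(CCOc2ccc(-c3c(C)nc(C)c([C@H](OC(C)(C)C)C(=O)O)c3N3CCC(C)(C)CC3)cc2)ccc1F`, an ADME assay on microsomes from liver (Rattus norvegicus) for metabolic stability, read by LC-MS, tested at 0.5 uM; on this read-out lower numbers stand for a shorter-lived compound and higher numbers for a longer-lived compound: > 2 h (a limit of this assay, not a number)
compound 2, `Cc1nc(C)c([C@H](OC(C)(C)C)C(=O)O)c(N2CCC(C)(C)CC2)c1-c1ccc(OCCc2ccc(F)c(F)c2)cc1`, this assay: 0.85 h

Among the measured compounds shown here, compound 2 holds the only number in this assay; the value of compound 1 is a limit (the limit of > 2 h in this assay, at which 1 of the 2 values shown sits). For the measured compounds named here, the step of an at least 2.3-fold lower number from compound 1 to compound 2 (0.37 log units; beyond the scatter) is the single measured step. Compound 3, `Cc1nc(C)c([C@H](OC(C)(C)C)C(=O)O)c(N2CCC(C)(C)CC2)c1-c1ccc(OCCCc2ccc(F)cc2)cc1`, carries 4-fluorobenzyl in place of 3,4-difluorophenyl on a saturated chain carbon, two bonds along the chain from an oxygen on an aromatic ring. Going by the values given here, no measured step covers this change, so the measured step gives no direction for it. The expectation for compound 3 is a 1.2-fold lower number from compound 2 to compound 3 (0.08 log units; within the scatter), so an estimate of 0.7 h (range 0.3 h to 1.6 h).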

Compound 3, half-life: > 2 h
Compound 3 ended at the assay's limit; the forecaster's own chance of this, stated with the estimate: 5%; middle value at least 2.8-fold (0.45 log units) away from the limit.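

Going from 2-(3,4-difluorophenyl)ethoxy to 3-(4-fluorophenyl)propoxy gives an at least 2.3-fold higher number from compound 2 to compound 3 (0.37 log units; beyond the scatter) in this assay, so a change in the chain at this place can also raise the half-life, which the earlier step on the aromatic ring did not show. This change alters the chain and the ring fluorines together, and the compounds shown do not separate the two. The step between compound 1 and compound 3 cannot be read, and the true size of the rise stays open: the limit of > 2 h in this assay, at which 2 of the 3 values shown sit.

Open, from the compounds shown here alone, is how a 3-(3,4-difluorophenyl)propoxy chain or a 2-(4-fluorophenyl)ethoxy chain would behave, either of which would separate chain length from ring fluorine.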